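Triazole substituent swap on the furanone series: compound 4

The source may report more compounds than this note shows. Statements on the series, on what has been measured and on what is new or still open speak of the compounds shown alone.

Measured so far in a functional assay on CFPAC-1 cells (Homo sapiens) for antiproliferative activity, read by MTT assay, with a stated time of 72 h; on this read-out lower numbers stand for stronger inhibition and higher numbers for weaker inhibition:
- compound 1 `O=C1O[C@H]([C@@H](O)Cn2cc(-c3ccc(Br)cc3)nn2)C(OCc2ccccc2)=C1OCc1ccccc1` gives 5830 nM
- compound 2 `O=C1O[C@H]([C@@H](O)Cn2cc(CNS(=O)(=O)c3ccc(F)cc3)nn2)C(OCc2ccccc2)=C1OCc1ccccc1` gives 34700 nM
- compound 3 `Cc1ccc(-c2cn(C[C@H](O)[C@H]3OC(=O)C(OCc4ccccc4)=C3OCc3ccccc3)nn2)cc1` reports only the limit > 100000 nM, not a number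

Compound 3 stands at the weak end of the three, at the assay limit (the limit of > 100000 nM in this assay, at which 1 of the 3 values shown sits); its distance from compound 1 is an at least 17-fold higher number from compound 1 to compound 3 (1.23 log units; beyond the scatter), and from compound 2 it is an at least 2.8-fold higher number from compound 2 to compound 3 (0.45 log units; beyond the scatter).

Compound 4 `Cc1ccc(S(=O)(=O)NCc2cn(C[C@H](O)[C@H]3OC(=O)C(OCc4ccccc4)=C3OCc3ccccc3)nn2)cc1` differs from compound 3 by (((4-methylphenyl)sulfonyl)amino)methyl in place of 4-methylphenyl on an aromatic carbon.

Among the measured compounds shown here, the step that bears on this change is the one from the aryl-substituted compound 1 to the sulfonamide compound 2, a 6.0-fold higher number from compound 1 to compound 2 (0.77 log units; beyond the scatter), a modest loss. Compound 4 carries the same sulfonamide linkage as compound 2, with a methyl rather than fluoro on the distal ring. Since compound 3 is itself only a limit, the direction of the step cannot be tight; compound 4 is expected to land near compound 2 or somewhat weaker, an expected step of an at least 2.2-fold lower number from compound 3 to compound 4 (0.34 log units; beyond the scatter) in this assay.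

Compound 4 is estimated at 45000 nM, within 15000 nM to 130000 nM.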

Compound 4, half-maximal inhibitory concentration: 68000 nM
Compound 4: the middle estimate sits 1.5-fold (0.18 log units) below what was measured; the measured number falls inside the stated range.
By their numbers in this assay, from the lowest: compound 1; then compounds 2 and 4 (each within the scatter of the next). At a limit, above all of these: compound 3.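

In this assay, the swap of methyl for fluoro on an aromatic carbon within the sulfonamide group gives a 2.0-fold higher number from compound 2 to compound 4 (0.29 log units; within the scatter), so this pair shows no readable effect of that change. A second sulfonamide also falls well short of the 4-bromophenyl group, at a 12-fold higher number from compound 1 to compound 4 (1.07 log units; beyond the scatter), a large step beyond the scatter, so the loss at this position is no longer seen with compound 2 alone. Against the 4-methylphenyl group, the sulfonamide gives an at least 1.4-fold lower number from compound 3 to compound 4 (0.16 log units; that floor lies within the scatter), a floor within the scatter, and compound 3 is only a limit, not a number: the limit of > 100000 nM in this assay, at which 1 of the 4 values shown sits.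

Going by these compounds, how far compound 3 truly lies from compound 4 stays open, and with it whether the longer sulfonamide group gives any real gain over 4-methylphenyl. Also open, on these data alone, is how a simple amine, a carboxylic acid or a longer chain on the same aromatic carbon would compare with the 4-bromophenyl group of compound 1.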